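This account rests on a few compounds, and the source may have more. Where it says the series, first, only, none or still open, it means among the compounds named here.

Of the compounds shown here, three built on one shared core have been measured in a functional assay on OVCAR-4 cells (Homo sapiens) for inhibition, read by sulforhodamine B assay, with a stated time of 48 h; a higher number here means a weaker inhibitor of growth, a lower number a stronger inhibitor of growth. Compound 1 `COc1cc(-c2nn(-c3cccc(NC(=O)Nc4cccc(C(F)(F)F)c4)c3)cc2-c2ccncc2)ccc1Cl` gives 2100 nM, while compound 2 `COc1cc(-c2nn(-c3cccc(NC(=O)Nc4ccc(Cl)c(C(F)(F)F)c4)c3)cc2-c2ccncc2)ccc1Cl` gives 25600 nM, which is the higher of the two numbers; the step of a 12-fold higher number from compound 1 to compound 2 (1.09 log units; beyond the scatter) arises from chloro in place of hydrogen on an aromatic carbon. Compound 3 `COc1cc(-c2nn(-c3cccc(NC(=O)c4ccccc4)c3)cc2-c2ccncc2)ccc1Cl` reaches only the limit of this assay, > 100000 nM. The remaining steps, an at least 47-fold higher number from compound 1 to compound 3 (1.67 log units; beyond the scatter) and an at least 3.9-fold higher number from compound 2 to compound 3 (0.59 log units; beyond the scatter), both follow replacement of the urea-side amino group by phenyl on the carbonyl carbon.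

Compound 4 `O=C(Nc1cccc(-n2cc(-c3ccncc3)c(-c3ccc(Cl)c(O)c3)n2)c1)Nc1ccc(Cl)c(C(F)(F)F)c1` has not yet been measured. It differs from compound 2 by hydrogen in place of methyl on an oxygen on an aromatic ring, that is, methoxy to hydroxy on the 4-chloro-3-methoxyphenyl ring. Among the measured compounds shown here, none of the measured steps touches this part of the molecule: each of them alters the urea or amide end instead. With no direct guide, the expectation is a step of a 1.0-fold lower number from compound 2 to compound 4 (0.01 log units; within the scatter), which is within the scatter in either direction. Compound 4 is therefore estimated at 25000 nM in this assay, with a range from 6000 nM to 100000 nM.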

Compound 4, concentration for total growth inhibition: > 32500 nM
Compound 4: only a limit was reported; the forecaster's own chance of this, stated with the estimate: 12%; middle value at least 1.3-fold (0.11 log units) away from the limit.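

Among the compounds shown here, this is the first change on the 4-chloro-3-methoxyphenyl ring rather than at the urea or amide end, and it shows that swapping methoxy for hydroxy on this ring does not give a stronger inhibitor of growth than compound 2. The change gives an at least 1.2-fold higher number from compound 2 to compound 4 (0.10 log units; that floor lies within the scatter), so the data cannot separate a real weakening from no change at all. Compound 4 is reported only as a limit, not as a number: the limit of > 32500 nM in this assay, at which 1 of the 4 values shown sits.

The compounds shown leave open how far the true number of compound 4 lies beyond that limit, and whether the same methoxy to hydroxy change would read differently on the urea of compound 1. They also leave open what a longer chain on this oxygen, such as ethoxy, or an amine in place of the methoxy would do.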